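Cyclohexylamino replacing arylamino on the shared quinone-fused core

The source may hold more compounds than are shown below. What is called first, only, known or untested is meant among the compounds shown, and "the series" means these compounds.

Measured so far:
- compound 1 `Cc1ccc(NC2=CC(=O)c3c(nc4n3[C@H]3OC[C@@H](O)[C@H]3OC4)C2=O)cc1C`: 4950 nM
- compound 2 `O=C1C=C(Nc2ccc(Br)cc2)C(=O)c2c1nc1n2[C@H]2OC[C@@H](O)[C@H]2OC1`: 2580 nM

In a functional assay on MCF7 cells (Homo sapiens) for inhibition, read by sulforhodamine B assay (on this read-out higher numbers stand for weaker inhibition and lower numbers for stronger inhibition), compound 1 gives 4950 nM. Among the compounds with values here, compound 2, the only other measured member, gives 2580 nM in this assay. The gap between these two numbers is within the usual scatter, so compound 1 and compound 2 are not separated by the data and neither can be called the stronger or weaker inhibitor. Both carry a substituted phenyl on the amine nitrogen attached to the core, so nothing measured yet speaks to a non-aromatic group at that position.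

Within the data shown here, compound 3 `O=C1C(NC2CCCCC2)=CC(=O)c2c1nc1n2[C@H]2OC[C@@H](O)[C@H]2OC1` is the first such case: cyclohexyl in place of 3,4-dimethylphenyl on an amine nitrogen. Among the measured compounds shown here, no measured pair shows a step of this kind, so the expected size rests on the change alone. A small step toward higher numbers in this assay is expected from compound 1 to compound 3, not clearly beyond the scatter, a 1.4-fold higher number from compound 1 to compound 3 (0.15 log units; within the scatter). For compound 3 the estimate in this assay is 7000 nM, with a range from 2000 nM to 25000 nM.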

Compound 3, half-maximal inhibitory concentration: > 16000 nM
Compound 3 ended at the assay's limit (the forecaster's own chance of this, stated with the estimate: 10%); at least 2.2-fold (0.35 log units) between middle value and limit.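

In this assay, within the data shown here, cyclohexyl in place of 3,4-dimethylphenyl on the amine nitrogen gives an at least 3.2-fold higher number from compound 1 to compound 3 (0.50 log units; beyond the scatter), the first step at this position that is printed as beyond the scatter. The value of compound 3 is a limit of the assay and not a number: the limit of > 16000 nM in this assay, at which 1 of the 3 values shown sits. The group on this amine nitrogen therefore matters in this series: compound 1 and compound 2, both with a substituted phenyl, stay within the scatter of each other, whereas the non-aromatic cyclohexyl of compound 3 gives a clearly higher number than compound 1.

This single step changes the ring from aromatic to non-aromatic and also changes the heavy-atom count of the group, from 8 to 6, so the compounds shown cannot separate these two differences, and the full size of the step stays unknown. Also open, on these data alone, is whether an unsubstituted phenyl, a pyridine ring or a morpholine ring on the same amine nitrogen would stay near compound 1 or move toward compound 3.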